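Phenyl Replaces Chlorophenyl in a Trimethoxyphenyl Chalcone Series

This account rests on a few compounds, and the source may have more. Where it says the series, first, only, none or still open, it means among the compounds named here.

In a functional assay on A549 cells (Homo sapiens) for antiproliferative activity, read by MTT assay, with a stated time of 24 h (on this read-out higher numbers stand for weaker inhibition and lower numbers for stronger inhibition), the three measured compounds stand as follows:
compound 1 `COc1cc(-c2cc(/C=C/C(=O)c3ccc(C)c(C)c3)nc3cc(-c4ccccc4)nn23)cc(OC)c1OC`: 10600 nM
compound 2 `COc1cc(-c2cc(C(=O)/C=C/c3ccc(C)cc3)nc3cc(-c4ccccc4)nn23)cc(OC)c1OC`: 20000 nM
compound 3 `COc1cc(-c2cc(C(=O)/C=C/c3ccc(Cl)cc3)nc3cc(-c4ccccc4)nn23)cc(OC)c1OC`: 23800 nM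

Compound 3 gives the highest number of the three; compound 2 is nearest to it, and only the gap to compound 1 lies beyond the scatter, as a 2.2-fold higher number from compound 1 to compound 3 (0.35 log units; beyond the scatter) shows. Compound 4 `COc1cc(-c2cc(/C=C/C(=O)c3ccccc3)nc3cc(-c4ccccc4)nn23)cc(OC)c1OC` differs from compound 3 by 2-benzoylethenyl in place of (2-(4-chlorophenyl)ethenyl)carbonyl on an aromatic carbon. The step that bears most on this is a 1.2-fold higher number from compound 2 to compound 3 (0.08 log units; within the scatter), which left the number where it was; a 1.9-fold higher number from compound 1 to compound 2 (0.28 log units; within the scatter) also stayed within the scatter. For the measured compounds named here, nothing among the measured compounds points to a shift beyond the scatter in this assay when 2-benzoylethenyl replaces (2-(4-chlorophenyl)ethenyl)carbonyl, so compound 4 is expected to sit close to compound 3, with a 1.3-fold lower number from compound 3 to compound 4 (0.12 log units; within the scatter). Compound 4 is estimated at 18000 nM, with a range from 8000 nM to 40000 nM.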

Compound 4, half-maximal inhibitory concentration: 18200 nM
Estimate against measurement, compound 4: 1.0-fold (0.00 log units) below; the range from low to high includes it.
By their numbers in this assay, from the lowest: compounds 1, 4, 2 and 3 (each within the scatter of the next, the first and the last beyond it).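

In this assay, 2-benzoylethenyl on this aromatic carbon stays within the scatter of both (2-(4-chlorophenyl)ethenyl)carbonyl, with a 1.3-fold lower number from compound 3 to compound 4 (0.12 log units; within the scatter), and (2-(4-methylphenyl)ethenyl)carbonyl, with a 1.1-fold lower number from compound 2 to compound 4 (0.04 log units; within the scatter). For the compounds shown here, compound 4 also gives the first comparison with the carbonyl group kept in place, and phenyl in place of 3,4-dimethylphenyl stays within the scatter too, with a 1.7-fold higher number from compound 1 to compound 4 (0.23 log units; within the scatter). No measured evidence explains these results. On these data alone, whether an amine or a carboxylic acid on that phenyl ring would shift the number beyond the scatter remains open.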